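Sulfonyl substituent swap in a pancreatic cell growth series

The source may report more compounds than this note shows. Statements on the series, on what has been measured and on what is new or still open speak of the compounds shown alone.

Among the compounds with values here, compound 1 `CCN(CC)S(=O)(=O)c1ccc(S(=O)(=O)N2CCC[C@@H](C(=O)NC3CN(C(=O)OC(C)(C)C)C3)C2)cc1` and compound 2 `CC(C)c1noc(N2CCN(C(=O)[C@@H]3CCCN(S(=O)(=O)c4ccc(S(=O)(=O)C5CCC5)cc4)C3)CC2)n1` are the two measured members; compound 3 `CCNS(=O)(=O)c1ccc(S(=O)(=O)N2CCC[C@@H](C(=O)N3CCN(c4nc(C(C)C)no4)CC3)C2)cc1` is the unmeasured one. In a functional assay on MIA PaCa-2 cells (Homo sapiens) for inhibition, read by MTT assay, with a stated time of 3 days (on this read-out higher numbers stand for weaker inhibition and lower numbers for stronger inhibition), compound 1 gives > 10000 nM, only a limit rather than a number. In this assay compound 2 gives > 10000 nM, again only a limit. Both measured values sit at the limit of > 10000 nM in this assay, at which 2 of the 2 values shown sit, so compound 2 stands at that limit and nowhere more precise. Compound 3 differs from compound 2 by ethylamino in place of cyclobutyl on a sulfonyl sulfur. Within the data shown here, no step between measured compounds is available; the expected step is none beyond the scatter. Compound 3 is estimated at 15000 nM, expected between 5000 nM and 50000 nM. The expected step that the limit leaves unreadable from compound 2 to compound 3 is thus essentially flat.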

Compound 3, half-maximal inhibitory concentration: > 10000 nM
Compound 3 gave a limit, no number; the forecaster's own chance of this, stated with the estimate: 80%; the middle value lies beyond the limit too.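

No step can be read from compound 2 to compound 3, because both values are limits rather than numbers: the limit of > 10000 nM in this assay, at which 3 of the 3 values shown sit. The compounds shown leave open whether ethylamino or cyclobutyl on the sulfonyl sulfur makes any difference to inhibition.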